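The source may report more compounds than this note shows. Statements on the series, on what has been measured and on what is new or still open speak of the compounds shown alone.

Three compounds have been measured in an assay on HEK293 cells for displacement of a labelled ligand from Melanocortin receptor 4 (Homo sapiens); a higher number here means a weaker inhibitor, a lower number a stronger inhibitor:

Compound 1 `COc1cc(CC(C)C(=O)N2CCN(c3ccc(C(F)(F)F)cc3[C@@H](N)CC(C)C)CC2)ccc1Cl` gives 230 nM.
Compound 2 `CC(C)C[C@H](N)c1cc(C(F)(F)F)ccc1N1CCN(C(=O)COc2cccc(Cl)c2Cl)CC1` gives 2500 nM.
Compound 3 `CC(C)C[C@H](N)c1cc(C(F)(F)F)ccc1N1CCN(C(=O)CCC(=O)N(C)C)CC1` gives only > 10000 nM, which is a limit of the assay rather than a number.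

Compound 3 thus stands as the weakest of the three, sitting at the limit of > 10000 nM in this assay, at which 1 of the 3 values shown sits. Compound 4 `Cc1ccc(CC(C)C(=O)N2CCN(c3ccc(C(F)(F)F)cc3[C@@H](N)CC(C)C)CC2)cc1C` has not yet been measured; it differs from compound 3 by 1-(3,4-dimethylbenzyl)ethyl in place of 2-(dimethylcarbamoyl)ethyl on a carbonyl carbon. The measured step that bears most on this runs the other way: an at least 43-fold higher number from compound 1 to compound 3 (1.63 log units; beyond the scatter), where a 1-(4-chloro-3-methoxybenzyl)ethyl group closely resembling the incoming 1-(3,4-dimethylbenzyl)ethyl was removed. A smaller shift, an at least 4.0-fold higher number from compound 2 to compound 3 (0.60 log units; beyond the scatter), points the same way. Putting such a group back on the carbonyl carbon is therefore expected to give a large drop in the number, an at least 33-fold lower number from compound 3 to compound 4 (1.52 log units; beyond the scatter). Compound 4 is estimated at 300 nM, within 80 nM to 1500 nM.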

Compound 4, inhibition constant: 240 nM
Compound 4: the middle estimate sits 1.3-fold (0.10 log units) above what was measured; low and high end bracket the measured number.
By their numbers in this assay, from the lowest: compounds 1 and 4 (each within the scatter of the next); then compound 2. At a limit, above all of these: compound 3.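

In this assay, a second aryl-bearing group on the carbonyl carbon now gives the same kind of gain: 1-(3,4-dimethylbenzyl)ethyl brings an at least 41-fold lower number from compound 3 to compound 4 (1.61 log units; beyond the scatter), and also a 10-fold lower number from compound 2 to compound 4 (1.02 log units; beyond the scatter). For compound 3, the value > 10000 nM is a limit of the assay and not a number. Changing only the ring, with 3,4-dimethylphenyl in place of 4-chloro-3-methoxyphenyl, gives a 1.0-fold higher number from compound 1 to compound 4 (0.02 log units; within the scatter), so these two rings cannot be told apart here. On these data alone, whether a plain benzyl group, a longer chain to the ring, or an amine or carboxylic acid on the ring would keep this level stays open.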